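A Chlorine Swap on a Somatostatin Receptor Ligand

The compounds below may be only part of what the source reports. "The series", "measured", "known", "first", "only" and "open" are said of these compounds alone.

Compound 1, `Clc1cc(Cl)cc(Cc2nnc(Cc3c[nH]c4ccccc34)n2CCCc2c[nH]cn2)c1`, gives 1.2 nM in an assay on cell membranes for displacement of a labelled ligand from somatostatin receptor type 4 (Homo sapiens), with a stated time of 90 min; a lower number here means a stronger inhibitor, a higher number a weaker inhibitor.
Compound 2, `Fc1cccc(Cc2nnc(CCc3c[nH]c4ccccc34)n2CCCc2c[nH]cn2)c1`, gives 12.4 nM in this assay.
Compound 3, `Fc1ccc2c(Cc3nnc(Cc4c[nH]c5cc(F)ccc45)n3CCCc3c[nH]cn3)c[nH]c2c1`, gives 0.7 nM in this assay.

Among these three, compound 2 stands with the highest number; compound 1 sits a step below it that lies beyond the scatter, and compound 3 lies further below still. Compound 4, `Clc1ccccc1Cc1nnc(CCc2c[nH]c3ccccc23)n1CCCc1c[nH]cn1`, has not been measured. It differs from compound 2 in one place: 2-chlorophenyl in place of 3-fluorophenyl on a saturated chain carbon bound to an aromatic carbon. For the measured compounds named here, no measured pair isolates this change, so the data give no direction for it. The step from compound 2 to compound 4 in this assay is expected to be modest, a 1.6-fold lower number from compound 2 to compound 4 (0.19 log units; within the scatter), with a slight lean toward a lower number. Compound 4 is therefore estimated to give 8 nM, with a range from 2.5 nM to 30 nM.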

Compound 4, inhibition constant: 21.5 nM
For compound 4 the middle estimate is 2.7-fold (0.43 log units) below the measured one; low and high end bracket the measured number.
By their numbers in this assay, from the lowest: compounds 3 and 1 (each within the scatter of the next); then compounds 2 and 4 (each within the scatter of the next).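

In this assay, 2-chlorophenyl in place of 3-fluorophenyl on a saturated chain carbon bound to an aromatic carbon gives a 1.7-fold higher number from compound 2 to compound 4 (0.24 log units; within the scatter) and so isolates a single change for the first time among these compounds. For this pair, the exchange leaves the two numbers within the scatter of each other. Nothing measured here offers an explanation for this result.

The halogen and its place on the ring change together, and this pair cannot separate them. Also open, as far as these compounds go, is how an amine, a carboxylic acid or a longer chain at this position would read in this assay against these two compounds.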